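A Hydroxy Group Gives Way to Nitro

The source may hold more compounds than are shown below. What is called first, only, known or untested is meant among the compounds shown, and "the series" means these compounds.

- Compound 1 `O=c1oc2ccccc2c2nc3c(ccc4cc[nH]c43)c(-c3ccccn3)c12`: 70700 nM
- Compound 2 `O=c1oc2ccccc2c2nc3c(ccc4cc[nH]c43)c(-c3ccc(O)cc3)c12`: 70700 nM

In a functional assay on B16-F10 cells (Mus musculus) for cytotoxicity (on this read-out higher numbers stand for weaker inhibition and lower numbers for stronger inhibition), compound 2 gives 70700 nM, level with compound 1. Compound 3 `O=c1oc2ccccc2c2nc3c(ccc4cc[nH]c43)c(-c3ccc([N+](=O)[O-])cc3)c12` keeps the same core and differs from compound 2 by one change: nitro in place of hydroxy on an aromatic carbon. Among the measured compounds shown here, the only measured step that bears on this is no change at the digits printed from compound 1 to compound 2 (within the scatter). That single step involves a different pair of groups, so it is weak guidance, but it offers no reason to expect a shift beyond the scatter in this assay. The expected change is a 1.2-fold lower number from compound 2 to compound 3 (0.07 log units; within the scatter). For compound 3 the estimated value is 60000 nM, with an expected range of 20000 nM to 120000 nM.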

Compound 3, half-maximal inhibitory concentration: 70700 nM
The estimate for compound 3 lay 1.2-fold (0.07 log units) below the measured number; the measured number falls inside the stated range.
By their numbers in this assay, from the lowest: compounds 1, 2 and 3 (each within the scatter of the next).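

In this assay nitro in place of hydroxy gives no change at the digits printed from compound 2 to compound 3 (within the scatter) and 4-nitrophenyl in place of pyridin-2-yl gives no change at the digits printed from compound 1 to compound 3 (within the scatter) so all three groups at this position now stand level. The hydrogen-bond donor of hydroxy can therefore go, and a larger group with more acceptors can enter, without any shift beyond the scatter. From the compounds shown here alone, whether an amine, a carboxylic acid or a longer chain here would move the number remains open. No measurement at hand explains why these three groups read alike.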